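Ester in place of methoxy on the benzyl thioether

The source may report more compounds than this note shows. Statements on the series, on what has been measured and on what is new or still open speak of the compounds shown alone.

Compound 1 `O=C(O)Cn1c(SCCNc2ccccc2)nc2ccccc21` and compound 2 `COc1ccccc1CSc1nc2ccccc2n1CC(=O)O` share the same core and differ in the group carried on the thioether. In an assay on HEK293 cells for displacement of a labelled ligand from prostaglandin D2 receptor 2 (Homo sapiens) (on this read-out higher numbers stand for weaker inhibition and lower numbers for stronger inhibition), compound 1 gives 7690 nM; in this assay compound 2 gives 1100 nM, the lowest of the two numbers, and the gap to compound 1 is beyond the scatter. Compound 3 `COC(=O)c1ccccc1CSc1nc2ccccc2n1CC(=O)O` is the next member: relative to compound 2 it carries methoxycarbonyl in place of methoxy on an aromatic carbon. For the measured compounds named here, no pair of measured compounds isolates this change, so the expectation rests on compound 2 alone. The expected step of a 1.5-fold higher number from compound 2 to compound 3 (0.16 log units; within the scatter) is small, toward a slightly higher number, and not clearly beyond the scatter. For compound 3 the estimate in this assay is 1600 nM, with a range from 450 nM to 6000 nM, where the low end would match compound 2 and the high end would approach compound 1.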

Compound 3, half-maximal inhibitory concentration: 520 nM
Compound 3: middle estimate off by 3.1-fold (0.49 log units), on the high side, within the range that was stated.
By their numbers in this assay, from the lowest: compound 3; then compound 2; then compound 1.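

In this assay, methoxycarbonyl in place of methoxy on an aromatic carbon, ortho to a large group, gives a 2.1-fold lower number from compound 2 to compound 3 (0.33 log units; beyond the scatter): a modest step, but beyond the scatter, showing that this place on the benzyl thioether tolerates the larger ester without loss. For the compounds shown here, compound 1 and compound 2 differ in the whole group on the thioether, so only this pair isolates a change at this aromatic carbon. Nothing available accounts for the direction of the step.

Going by these compounds, whether the step belongs to the carbonyl or to the ester as a whole stays open; a carboxylic acid, a primary amide or a nitrile on the same aromatic carbon would separate the two. Also open, on these data alone, is how a plain benzyl group without any substituent compares with compound 2 and compound 3.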